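Ring closure on the thioether side chain of compound 2

This account rests on a few compounds, and the source may have more. Where it says the series, first, only, none or still open, it means among the compounds named here.

Compound 1: `CC(C)c1n[nH]c2c(NCc3ccc(-c4ccccn4)cc3)nc(SCC(O)CN)nc12` — 55 nM
Compound 2: `CC(C)c1n[nH]c2c(NCc3ccc(-c4ccccn4)cc3)nc(SC(C)C(C)O)nc12` — 190 nM
Compound 3: `CC(C)c1n[nH]c2c(NCc3ccc(-c4ccccn4)cc3)nc(SC3CCCCC3O)nc12` — 636 nM

In a functional assay on HT cells (Homo sapiens) for antiproliferative activity, read by fluorescence, with a stated time of 72 h (on this read-out lower numbers stand for stronger inhibition of growth and higher numbers for weaker inhibition of growth), compound 2 holds the middle place among the three measured compounds. The step to its nearest neighbour, compound 3, reads a 3.3-fold higher number from compound 2 to compound 3 (0.52 log units; beyond the scatter), and the step from compound 1 reads a 3.5-fold higher number from compound 1 to compound 2 (0.54 log units; beyond the scatter), so compound 2 stands apart from both beyond the scatter.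

Compound 4 is `CC(C)c1n[nH]c2c(NCc3ccc(-c4ccccn4)cc3)nc(SC3CCCC3O)nc12`. It differs from compound 2 in one place: 2-hydroxycyclopentyl in place of 2-hydroxy-1-methylpropyl on a sulfur. The change closes the open chain into a ring, much as the change from compound 2 to compound 3 does, where the ring entering is one carbon larger. That step, a 3.3-fold higher number from compound 2 to compound 3 (0.52 log units; beyond the scatter), was modest and upward, and the longer step of a 12-fold higher number from compound 1 to compound 3 (1.06 log units; beyond the scatter) points the same way. Within the data shown here, the 2-hydroxycyclopentyl group lies between the open chain of compound 2 and the six-membered ring of compound 3, so a step in this assay that is upward but smaller than the one to compound 3 is expected.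

Compound 4 is therefore expected to give about 380 nM in this assay, within a range of 190 nM to 800 nM, which would mean a step of a 2.0-fold higher number from compound 2 to compound 4 (0.30 log units; within the scatter).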

Compound 4, concentration for 50% growth inhibition: 567 nM
Estimate against measurement, compound 4: 1.5-fold (0.17 log units) below; measured number inside the range.
By their numbers in this assay, from the lowest: compound 1; then compound 2; then compounds 4 and 3 (each within the scatter of the next).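

In this assay, the new result shows that a five-membered carbon ring on the sulfur is already enough to move the number well away from the open chain of compound 2 (a 3.0-fold higher number from compound 2 to compound 4 (0.47 log units; beyond the scatter)), a move that the earlier compounds had shown only for the 2-hydroxycyclohexyl group. Ring size, which compound 3 alone could not address, makes no readable difference here, since 2-hydroxycyclopentyl and 2-hydroxycyclohexyl on the sulfur cannot be told apart (a 1.1-fold lower number from compound 3 to compound 4 (0.05 log units; within the scatter)). Against the 3-amino-2-hydroxypropyl chain of compound 1, the new ring leaves a large gap (a 10-fold higher number from compound 1 to compound 4 (1.01 log units; beyond the scatter)), so among these four compounds both ring-bearing members stand well apart from compound 1, and neither ring closes that gap.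

Nothing given here explains why closing the ring raises the number. The compounds shown also leave open whether a primary amine placed on the cyclopentyl ring, as in a 2-aminocyclopentyl group, would bring the number back toward that of compound 1, and whether a four-membered carbon ring bearing the same hydroxyl would behave like the two rings seen here.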